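The source may hold more compounds than are shown below. What is called first, only, known or untested is meant among the compounds shown, and "the series" means these compounds.

In a functional assay on U-373MG ATCC cells for inhibition, with U373 MG (Homo sapiens) as the target, read by MTT assay, with a stated time of 7 days (on this read-out lower numbers stand for stronger inhibition of growth and higher numbers for weaker inhibition of growth), compound 1 (`NC(=O)c1ncn2c(=O)n(Cc3ccccc3)nnc12`) gives > 50000 nM as a limit and not a number. Compound 2 (`NC(=O)c1ncn2c(=O)n(Cc3ccco3)nnc12`) gives > 50000 nM as a limit too. Both compounds thus rest at the limit of > 50000 nM in this assay, at which 2 of the 2 values shown sit, and no number separates them. Compound 3 (`Cc1cc(Cn2nnc3c(C(N)=O)ncn3c2=O)on1`) has 3-methyl-1,2-oxazol-5-yl in place of furan-2-yl on a saturated chain carbon bound to an aromatic nitrogen. Among the measured compounds shown here, the one measured step bearing on this is a step that the two limits leave unreadable from compound 1 to compound 2 at the same place, so no size can be carried over. A step beyond the scatter is therefore not expected in this assay for this change. The estimated step is a number no higher from compound 2 to compound 3 (the limit leaves the size open) on this reasoning. Compound 3 is estimated at 50000 nM with 25000 nM to 100000 nM as its expected range.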

Compound 3, concentration for 50% growth inhibition: > 50000 nM
Compound 3: only a limit was reported (the forecaster's own chance of this, stated with the estimate: 80%); the middle value lies on the limit itself.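

Compound 3 joins compound 1 and compound 2 at a limit and not a number, so no step among these three compounds can be read: the limit of > 50000 nM in this assay, at which 3 of the 3 values shown sit. The compounds shown leave open how phenyl, furan-2-yl and 3-methyl-1,2-oxazol-5-yl compare in growth inhibition.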